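This account rests on a few compounds, and the source may have more. Where it says the series, first, only, none or still open, it means among the compounds named here.

Of the compounds shown here, three built on the shared core have been measured so far. In a functional assay on A-375 cells (Homo sapiens) for antiproliferative activity (a higher number here means a weaker inhibitor, a lower number a stronger inhibitor), compound 1 `O=C(Nc1ccc(-c2cscn2)cc1)C1CCN(Cc2ccc(F)c(F)c2)CC1` gives > 20000 nM, which is a limit of the assay and not a number. Compound 2 `O=C(Nc1ccc(-c2cscn2)cc1)C1CCCN(C(=O)c2ccc(F)c(F)c2)C1` gives > 20000 nM in this assay, and this is also a limit. Compound 3 `O=C(NC1CCCN(Cc2ccc(F)c(F)c2)C1)c1ccc(-c2cscn2)cc1` gives > 20000 nM, again a limit. The series therefore stands at the limit of > 20000 nM in this assay, at which 3 of the 3 values shown sit. Within the data shown here, compound 2 thus has only a limit to its name, and no numerical step between measured compounds is available to serve as a guide.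

The next compound is compound 4 `O=C(Nc1ccc(-c2cscn2)cc1)C1CCCN(Cc2cc(F)cc(F)c2)C1`, which differs from compound 2 in one place: 3,5-difluorobenzyl in place of (3,4-difluorophenyl)carbonyl on an amine nitrogen in a ring. Here 3,5-difluorobenzyl comes in place of (3,4-difluorophenyl)carbonyl on an amine nitrogen in a ring. The expectation in this assay rests mostly on the limit for compound 2 of > 20000 nM. No change beyond the scatter is expected, and no direction can be favoured. The expected step is a number no higher from compound 2 to compound 4 (the limit leaves the size open), and this estimate is tied to a limit rather than a number. For compound 4 the estimated value is 20000 nM, with an expected range from 7000 nM to 30000 nM, and a report of only a limit is the likeliest outcome.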

Compound 4, half-maximal inhibitory concentration: 1360 nM
The estimate for compound 4 lay 15-fold (1.17 log units) above the measured number; measured number outside the range, below it.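

In this assay, among these compounds, compound 4 is the first of the series to give a number rather than a limit, at 1360 nM, so the group on the amine nitrogen in the ring is a place where this assay responds strongly. Putting 3,5-difluorobenzyl in place of (3,4-difluorophenyl)carbonyl brings an at least 14-fold lower number from compound 2 to compound 4 (1.16 log units; beyond the scatter), and this single swap removes the carbonyl and also alters the fluorine pattern on the aromatic ring. The true size of this step cannot be read, because compound 2 has only a limit, which leaves the step open-ended: the limit of > 20000 nM in this assay, at which 3 of the 4 values shown sit.

The compounds shown do not separate the loss of the carbonyl from the change in fluorine pattern, so either could account for the step. An unsubstituted benzyl group, a 3,5-difluorobenzoyl group or a pyridylmethyl group on the same nitrogen would help to tell these apart and would show whether the fluorines are needed at all.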